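The source may hold more compounds than are shown below. What is called first, only, known or untested is meant among the compounds shown, and "the series" means these compounds.

Measured so far in a physicochemical assay for solubility, read by HPLC, in phosphate buffer, at pH 6.5; a higher number here means a more soluble compound, a lower number a less soluble compound:

Compound 1, `OCCCNc1nnc(-c2ccc(F)c(F)c2Nc2ccc(I)cc2F)o1` — compound 1 sits at a limit of the assay, < 3 ug/mL.
Compound 2, `COCCCNc1nnc(-c2ccc(F)c(F)c2Nc2ccc(I)cc2F)o1` — compound 2 likewise sits at a limit of the assay, < 3 ug/mL.
Compound 3, `CNCCNc1nnc(-c2ccc(F)c(F)c2Nc2ccc(I)cc2F)o1` — compound 3 gives 6.7 ug/mL.

Going by the values given here, compound 3 carries the only number in this assay so far; the other two values are limits, as the limit of < 3 ug/mL in this assay, at which 2 of the 3 values shown sit, records. The step from compound 1 to compound 3 reads an at least 2.2-fold higher number from compound 1 to compound 3 (0.34 log units; beyond the scatter), and the step from compound 2 to compound 3 reads an at least 2.2-fold higher number from compound 2 to compound 3 (0.34 log units; beyond the scatter); the step that the two limits leave unreadable from compound 1 to compound 2 cannot be sized.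

Compound 4, `OCCCCCNc1nnc(-c2ccc(F)c(F)c2Nc2ccc(I)cc2F)o1`, is the next member. Against compound 3 the change is 3-hydroxypropyl in place of methylamino on a saturated chain carbon, two bonds along the chain from a nitrogen on an aromatic ring. Both measured steps that bear on it run the other way: replacing a hydroxymethyl or methoxymethyl chain end by methylamino lifted the number in this assay, in each case by at least a modest amount. Compound 4 gives the methylamino back up for a chain ending in a hydroxyl group, as compound 1 does. The expected direction is therefore downward, and a drop of a 3.4-fold lower number from compound 3 to compound 4 (0.53 log units; beyond the scatter) from compound 3 to compound 4 is expected, probably back to the limit. For compound 4 the estimate is 2 ug/mL, within 0.5 ug/mL to 6 ug/mL.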

Compound 4, solubility: < 3 ug/mL
Compound 4 ended at the assay's limit; the forecaster's own chance of this, stated with the estimate: 70%; the middle value does not contradict the limit.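

In this assay, the methylamino end of compound 3 now stands above a longer oxygen-ended chain as well as the two shorter ones: an at least 2.2-fold lower number from compound 3 to compound 4 (0.34 log units; beyond the scatter). Lengthening the chain to (5-hydroxypentyl)amino therefore gives no readable gain over the shorter hydroxyl-ended chain of compound 1, and the steps among compound 1, compound 2 and compound 4 cannot be read, as each has only a limit. Among the four compounds shown, only the chain ending in methylamino gives a number rather than a limit, no compound shown goes against this, and any order among the other three stays hidden: the limit of < 3 ug/mL in this assay, at which 3 of the 4 values shown sit.

Going by these compounds, a single chain ending in an amine carries the whole contrast, so it remains open whether a dimethylamino or a cyclic amine such as morpholine at the same chain end would also give a number, and whether a carboxylic acid there would do the same. On these data alone, it is equally open how the number would respond to a longer chain ending in methylamino, which would separate chain length from the identity of the end group.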